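Thiosemicarbazone aryl swap toward a methyl-bearing imine

This account rests on a few compounds, and the source may have more. Where it says the series, first, only, none or still open, it means among the compounds named here.

Compound 1: `CC1=CC[C@@H]([C@@](C)(O)CCCC(C)(C)NC(=S)N/N=C\c2ccc(C)cc2)CC1` — > 100000 nM in a functional assay on MCF7 cells (Homo sapiens) for cytotoxicity, read by sulforhodamine B assay; on this read-out lower numbers stand for higher toxicity in this test and higher numbers for lower toxicity in this test
Compound 2: `CC1=CC[C@@H]([C@@](C)(O)CCCC(C)(C)NC(=S)N/N=C\c2ccc(O)cc2)CC1` — 56400 nM in this assay
Compound 3: `CC1=CC[C@@H]([C@@](C)(O)CCCC(C)(C)NC(=S)N/N=C\c2cccc(Cl)c2)CC1` — 45900 nM in this assay

The value given for compound 1 in this assay is a limit of the assay, not a number (the limit of > 100000 nM in this assay, at which 1 of the 3 values shown sits). Among the two numbers that were read, compound 3 has the lowest, and compound 2 sits nearest to it: a 1.2-fold lower number from compound 2 to compound 3 (0.09 log units; within the scatter). Against compound 1 the step is larger: an at least 2.1-fold lower number from compound 1 to compound 3 (0.33 log units; beyond the scatter). The change from compound 2 to compound 3 and from compound 1 to compound 2, an at least 1.7-fold lower number from compound 1 to compound 2 (0.24 log units; that floor lies within the scatter), all touch the same aromatic part of the molecule and all move the number only a little.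

Compound 4, `CC1=CC[C@@H]([C@@](C)(O)CCCC(C)(C)NC(=S)N/N=C(/C)c2ccccc2)CC1`, changes that same region once more: a group of 9 heavy atoms (8 carbon, 1 nitrogen; one six-membered aromatic ring of carbon only) in place of a group of 9 heavy atoms (7 carbon, 1 nitrogen, 1 chlorine; one six-membered aromatic ring of carbon only), on an amide-type nitrogen. The three measured steps that bear on this move all stay small or at the edge of the scatter, so a step in this assay of similar size, most likely toward a higher number, is expected from compound 3 to compound 4, a 1.5-fold higher number from compound 3 to compound 4 (0.18 log units; within the scatter). The number for compound 4 in this assay is therefore estimated at 70000 nM, with a range from 30000 nM to 160000 nM.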

Compound 4, concentration lethal to 50% of the cells: > 100000 nM
Compound 4 was reported as a limit; the forecaster's own chance of this, stated with the estimate: 35%; middle value at least 1.4-fold (0.15 log units) away from the limit.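

In this assay the value for compound 4 is a limit, the same one that compound 1 reaches: the limit of > 100000 nM in this assay, at which 2 of the 4 values shown sit.

Replacing the 3-chlorophenyl-bearing group gives an at least 2.1-fold higher number from compound 3 to compound 4 (0.33 log units; beyond the scatter), a step beyond the scatter, whereas the floor of an at least 1.7-fold higher number from compound 2 to compound 4 (0.24 log units; that floor lies within the scatter) does not by itself clear the scatter. Across the four compounds, the two groups of 8 carbon and 1 nitrogen both end at the limit, while numbers were read only for the groups that contain oxygen or chlorine, compound 2 and compound 3; the step between compound 1 and compound 4 cannot be read, as both are limits.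

Compound 4 differs from compound 3 both in the methyl-bearing imine and in the absence of chlorine, so the compounds shown do not say which of the two accounts for the step, and a 3-chlorophenyl group on the methyl-bearing imine would separate them. They also leave open whether an amine or a carboxylic acid on the aromatic ring would give a readable number, or one that differs from those of compound 2 and compound 3.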